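Swapping Fluoro for Bromo on Compound 3

A few compounds are considered here, and "the series" means these few. Any claim that something is new, unique, unknown or untested is made for them only; others in the source may bear on it.

In a functional assay on A549 cells (Homo sapiens) for inhibition, read by MTT assay, with a stated time of 72 h (on this read-out lower numbers stand for stronger inhibition and higher numbers for weaker inhibition), compound 1 `CCc1ccc(NC(=O)C2CCN(C/C=C/c3ccccc3)CC2)cc1` gives 19600 nM, compound 2 `CCCc1ccc(NC(=O)C2CCN(C/C=C/c3ccccc3)CC2)cc1` gives 9470 nM, and compound 3 `O=C(Nc1cccc(F)c1)C1CCN(C/C=C/c2ccccc2)CC1` gives 43300 nM, the highest number of the three. Compound 4 `O=C(Nc1cccc(Br)c1)C1CCN(C/C=C/c2ccccc2)CC1` carries bromo in place of fluoro on an aromatic carbon. Among the compounds with values here, no measured step makes this exact swap. The closest guide is a small enlargement elsewhere, a 2.1-fold lower number from compound 1 to compound 2 (0.32 log units; beyond the scatter). The steps of a 2.2-fold higher number from compound 1 to compound 3 (0.34 log units; beyond the scatter) and a 4.6-fold higher number from compound 2 to compound 3 (0.66 log units; beyond the scatter) replace a whole aromatic group, and both are also modest. A modest step toward a lower number is therefore expected in this assay. The expected step is a 1.6-fold lower number from compound 3 to compound 4 (0.21 log units; within the scatter). Compound 4 is estimated at 27000 nM, with an expected range of 12000 nM to 50000 nM.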

Compound 4, half-maximal inhibitory concentration: 16500 nM
The estimate for compound 4 lay 1.6-fold (0.21 log units) above the measured number; low and high end bracket the measured number.
By their numbers in this assay, from the lowest: compounds 2, 4 and 1 (each within the scatter of the next, the first and the last beyond it); then compound 3.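

Exchanging fluoro for bromo on this one aromatic carbon shifts the number by itself (a 2.6-fold lower number from compound 3 to compound 4 (0.42 log units; beyond the scatter)), so in this assay this position is sensitive to which of these two groups it carries. With bromo in place, the 3-bromophenyl group also matches the alkyl-bearing phenyl groups, with a 1.2-fold lower number from compound 1 to compound 4 (0.07 log units; within the scatter) and a 1.7-fold higher number from compound 2 to compound 4 (0.24 log units; within the scatter) both within the scatter. No measurement at hand explains why the swap changes the number. Two groups at one carbon cannot define a trend. On these data alone, whether chloro, iodo, an amine or a carboxylic acid at this carbon would give a lower or higher number remains open.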